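A few compounds are considered here, and "the series" means these few. Any claim that something is new, unique, unknown or untested is made for them only; others in the source may bear on it.

Measured so far in an in vitro assay on SH-EP1 cells for displacement of a labelled ligand from Neuronal acetylcholine receptor; alpha4/beta2 (Homo sapiens); on this read-out lower numbers stand for stronger inhibition and higher numbers for weaker inhibition:
compound 1 `CN1CC2C=C(c3cncc(C#N)c3)CC(C2)C1`, 24 nM
compound 2 `CN1CC2C=C(c3cncc(Cl)c3)CC(C2)C1`, 9.6 nM

Compound 2 gives the lowest of the two numbers; the nearest is compound 1, separated by the step of a 2.5-fold lower number from compound 1 to compound 2 (0.40 log units; beyond the scatter). Compound 3 `CC(C)Oc1cncc(C2=CC3CC(C2)CN(C)C3)c1` differs from compound 2 by isopropoxy in place of chloro on an aromatic carbon. For the measured compounds named here, no measured step covers this change; the only step in hand, a 2.5-fold lower number from compound 1 to compound 2 (0.40 log units; beyond the scatter), concerns a different substituent on the same aromatic carbon and so bears on it only loosely. The step to compound 3 is therefore expected to be small, a 1.6-fold higher number from compound 2 to compound 3 (0.19 log units; within the scatter), with no firm direction. Compound 3 is estimated at 15 nM, in the range 4 nM to 55 nM.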

Compound 3, inhibition constant: 2.2 nM
Compound 3: middle estimate off by 6.8-fold (0.83 log units), on the high side, outside the stated range (below it).
By their numbers in this assay, from the lowest: compound 3; then compound 2; then compound 1.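

In this assay, the substituent on this aromatic carbon, two atoms from the ring nitrogen, can carry more than a small group: isopropoxy, with 4 heavy atoms against 1 for chloro, gives a 4.4-fold lower number from compound 2 to compound 3 (0.64 log units; beyond the scatter) and an 11-fold lower number from compound 1 to compound 3 (1.04 log units; beyond the scatter). Isopropoxy, the only one of the three groups with an oxygen, therefore gives the lowest number at this position. No evidence is at hand to explain this gain. The compounds shown leave open whether the oxygen or the branched carbon part carries the gain. Methoxy, a longer alkoxy chain or an amine on the same carbon would address this.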